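From chloro to bromo on the aromatic ring

The source may report more compounds than this note shows. Statements on the series, on what has been measured and on what is new or still open speak of the compounds shown alone.

For the measured compounds named here, in a functional assay on SGC-7901 cells (Homo sapiens) for antiproliferative activity, read by MTT assay, with a stated time of 48 h (on this read-out lower numbers stand for an effect already at smaller amounts and higher numbers for an effect only at larger amounts of compound), compound 1 (`CC1=NN(C(=O)CCl)C(c2cc(Cl)ccc2O)C1`) gives 14000 nM and holds the middle place among the three compounds measured so far. Compound 2 (`CC1=NN(C(=O)CBr)C(c2ccccc2O)C1`) gives a lower number at 4180 nM and compound 3 (`CC1=NN(C(=O)c2ccc(F)cc2)C(c2ccccc2O)C1`) a higher one at 50300 nM with both gaps to compound 1 lying beyond the scatter.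

The next compound, compound 4 (`CC1=NN(C(=O)CCl)C(c2cc(Br)ccc2O)C1`), keeps the core of compound 1 and carries one change: bromo in place of chloro on an aromatic carbon that is, bromo in place of chloro on an aromatic carbon, para to a hydroxy group.

Going by the values given here, the only measured step, a 12-fold higher number from compound 2 to compound 3 (1.08 log units; beyond the scatter) with 4-fluorophenyl in place of bromomethyl on a carbonyl carbon, is large but lies at another place in the structure and so gives no direct guide here. No exchange of halogens on the aromatic carbon has been measured. The expectation therefore rests on compound 1 at 14000 nM alone, and no step beyond the scatter is expected in this assay for this change. The expected step is a 1.2-fold lower number from compound 1 to compound 4 (0.07 log units; within the scatter) and this estimate stays within the scatter. For compound 4 the estimated value is 12000 nM with an expected range from 5500 nM up to 27000 nM as its upper end.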

Compound 4, half-maximal effective concentration: 9210 nM
The estimate for compound 4 lay 1.3-fold (0.11 log units) above the measured number; the measured number falls inside the stated range.
By their numbers in this assay, from the lowest: compound 2; then compounds 4 and 1 (each within the scatter of the next); then compound 3.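

In this assay, for the compounds shown here, the pair compound 1 and compound 4 gives the first direct reading at this aromatic carbon, para to a hydroxy group, and bromo in place of chloro there gives a 1.5-fold lower number from compound 1 to compound 4 (0.18 log units; within the scatter). Going by these compounds alone, with the rest of compound 1 held fixed, the two halogens therefore cannot be told apart at this position, whereas the one earlier step, a 12-fold higher number from compound 2 to compound 3 (1.08 log units; beyond the scatter), was large and lay at the carbonyl carbon, a different place in the structure. Nothing in the data explains why this exchange leaves the read-out within the usual scatter.

On these data alone, whether a group other than a halogen on this same aromatic carbon, such as a methoxy group, an amine or a carboxylic acid, would also stay within the scatter of compound 1 remains open. Also open, as far as these compounds go, is whether the exchange of chloro for bromo would read the same with 4-fluorophenyl on the carbonyl carbon, and compound 2 cannot settle what the ring halogen contributes, since it differs from compound 1 in more than one place.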